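Oxime to ketone on the thioether chain: series notes

The source may report more compounds than this note shows. Statements on the series, on what has been measured and on what is new or still open speak of the compounds shown alone.

Measured compounds in a functional assay on the whole organism (strain albino) for inhibition, with Rattus norvegicus as the target, read by paw edema, with a stated time of 2 h, at a dose of 0.28 mmol/kg by the oral route; a higher number here means more inhibition at the dose given (going by the name of the read-out), a lower number less inhibition:
- compound 1 `O/N=C(/CSc1nnc(-c2ccccc2)n1-c1ccccc1)c1ccccc1` gives 63%
- compound 2 `O=C(CSc1nnc(-c2ccccc2)n1-c1ccccc1)c1ccccc1` gives 60%
- compound 3 `CCn1c(SC/C(=N/O)c2ccccc2)nnc1-c1ccc(OC)c(OC)c1` gives 67%

Compound 1 and compound 2 share one core; compound 2 carries a group of 8 heavy atoms (7 carbon, 1 oxygen; one six-membered aromatic ring of carbon only) in place of a group of 9 heavy atoms (7 carbon, 1 nitrogen, 1 oxygen; one six-membered aromatic ring of carbon only), on a saturated chain carbon bound to a sulfur. The measured step is a number 3 percentage points lower from compound 1 to compound 2 (within the scatter). Compound 3 has a different core from compound 1; that difference is not broken down here. The values of compound 3, compound 1 and compound 2 in this assay all lie within the scatter of one another, so no order among the three can be read from them.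

Compound 4 `CCn1c(SCC(=O)c2ccccc2)nnc1-c1ccc(OC)c(OC)c1` has not been measured. It carries a group of 8 heavy atoms (7 carbon, 1 oxygen; one six-membered aromatic ring of carbon only) in place of a group of 9 heavy atoms (7 carbon, 1 nitrogen, 1 oxygen; one six-membered aromatic ring of carbon only), on a saturated chain carbon bound to a sulfur relative to compound 3, the same change as from compound 1 to compound 2, at the same place. The expected step in this assay is a number 3 percentage points lower from compound 3 to compound 4 (within the scatter), resting on the single earlier occurrence of this change, because a number 3 percentage points lower from compound 1 to compound 2 (within the scatter). One occurrence is a thin base, so the range is kept wide. Compound 4 is estimated at 64%, expected to fall between 54% and 74%.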

Compound 4, a percentage reported as inhibition, in the whole organism at one dose (the size of the read-out at that dose, not a potency): 55%
Estimate against measurement, compound 4: 9 percentage points above; low and high end bracket the measured number.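

In this assay, benzoyl in place of the oxime-bearing group, on a saturated chain carbon bound to a sulfur, gives a number 12 percentage points lower from compound 3 to compound 4 (beyond the scatter), set against a number 3 percentage points lower from compound 1 to compound 2 (within the scatter). The two steps cannot be told apart, so as far as these two pairs go, the change carries from the core of compound 1 to the core of compound 3 without a measurable difference between the cores: the same change on two cores in this assay, a number 3 percentage points lower (within the scatter) from compound 1 to compound 2 and a number 12 percentage points lower (beyond the scatter) from compound 3 to compound 4, 9 percentage points apart, within the scatter of two such steps

Among the compounds shown here, this does not show that the core has no influence on the step, and it does not fix the size of the step on any further core, since only two pairs at a single dose and a single time stand behind it.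

The compounds shown leave open how an oxime methyl ether, a hydrazone or an alcohol at the same place would read in this assay. Also open, going by these compounds, is whether a carboxylic acid or an amine in place of the benzoyl would keep the inhibition of paw edema seen with compound 3 or compound 1.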